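Adding a second fluoro to compound 2

This account rests on a few compounds, and the source may have more. Where it says the series, first, only, none or still open, it means among the compounds named here.

In a functional assay on HT-29 cells (Homo sapiens) for antiproliferative activity (a higher number here means a weaker inhibitor, a lower number a stronger inhibitor), compound 1 `COc1ccc(S(=O)(=O)N2CCc3cccc(Nc4ccccc4)c32)cc1` gives 343 nM and compound 2 `COc1ccc(S(=O)(=O)N2CCc3cccc(Nc4ccc(F)cc4)c32)cc1` gives 588 nM. Among the measured compounds shown here, these two numbers lie within the scatter of each other, so compound 2 stands level with the only other measured compound. The next structure, compound 3 `COc1ccc(S(=O)(=O)N2CCc3cccc(Nc4ccc(F)c(F)c4)c32)cc1`, turns the 4-fluorophenyl into 3,4-difluorophenyl: fluoro in place of hydrogen on an aromatic carbon. For the measured compounds named here, one measured step bears on this change, the same kind of replacement of hydrogen by fluoro on an aromatic carbon: a 1.7-fold higher number from compound 1 to compound 2 (0.23 log units; within the scatter). Going by the values given here, that single step stays within the scatter, and no measured pair shows the addition of a second fluoro. No shift beyond the scatter is therefore expected in this assay. For compound 3 the estimated value is 550 nM, with an expected range of 220 nM to 1400 nM. The estimated step is a 1.1-fold lower number from compound 2 to compound 3 (0.03 log units; within the scatter).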

Compound 3, half-maximal inhibitory concentration: 968 nM
Compound 3: middle estimate off by 1.8-fold (0.25 log units), on the low side; the range from low to high includes it.
By their numbers in this assay, from the lowest: compounds 1, 2 and 3 (each within the scatter of the next, the first and the last beyond it).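

In this assay the second fluoro, ortho to a fluoro group, gives a 1.6-fold higher number from compound 2 to compound 3 (0.22 log units; within the scatter) and so leaves 3,4-difluorophenyl level with 4-fluorophenyl at this position. Read against the unsubstituted phenyl, the same ring gives a 2.8-fold higher number from compound 1 to compound 3 (0.45 log units; beyond the scatter) as the first step in the series to pass the scatter, though only modestly, while each single fluoro replacement stays within it. No measurement available here accounts for this shift.

Open, going by these compounds, is whether a different group on this aromatic ring, such as methoxy, an amine or a carboxylic acid, would move the number further in either direction. Also open, on these data alone, is whether a group on this ring can bring the number below that of compound 1 343 nM by more than the scatter.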